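Fluoro addition in a series at the assay limit

The source may hold more compounds than are shown below. What is called first, only, known or untested is meant among the compounds shown, and "the series" means these compounds.

Measured in a functional assay on Jurkat cells (Homo sapiens); a higher number here means a weaker inhibitor, a lower number a stronger inhibitor:
compound 1 `CC(C)[C@H](NC(=O)COc1cccc2ccccc12)C(=O)N[C@@H](CC(=O)O)C(=O)COc1ccc(C(N)=O)cc1`: > 100000 nM (a limit)
compound 2 `CC(C)[C@H](NC(=O)COc1cccc2ccccc12)C(=O)N[C@@H](CC(=O)O)C(=O)COc1ccccc1F`: > 100000 nM (a limit)

In this assay compound 2 gives > 100000 nM, a limit and not a number. This is the limit of > 100000 nM in this assay, at which 2 of the 2 values shown sit. Compound 3 `CC(C)[C@H](NC(=O)COc1cccc2ccccc12)C(=O)N[C@@H](CC(=O)O)C(=O)COc1ccc(F)cc1F` follows from compound 2 by fluoro in place of hydrogen on an aromatic carbon. For the measured compounds named here, the only measured step is a step that the two limits leave unreadable from compound 1 to compound 2, and it offers no size to carry over. No step beyond the scatter is therefore expected, in either direction. The expected step is a number no higher from compound 2 to compound 3 (the limit leaves the size open). For compound 3 the estimate is 100000 nM, with an expected range of 20000 nM to 200000 nM.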

Compound 3, half-maximal inhibitory concentration: 33200 nM
Beside the measured number, compound 3's estimate is 3.0-fold (0.48 log units) above it; measured number inside the range.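

In this assay, for the compounds shown here, fluoro in place of hydrogen on the aromatic carbon para to a large group gives the first step of readable direction in this set: an at least 3.0-fold lower number from compound 2 to compound 3 (0.47 log units; beyond the scatter). Replacing 4-carbamoylphenyl with 2,4-difluorophenyl gives an at least 3.0-fold lower number from compound 1 to compound 3 (0.47 log units; beyond the scatter). The step between compound 1 and compound 2 cannot be read, and both of those values are limits: the limit of > 100000 nM in this assay, at which 2 of the 3 values shown sit.

On these data alone, the full size of both readable steps stays open. As far as these compounds go, whether a chloro or methoxy group on that same aromatic carbon would give a comparable number also stays open.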